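Shared-core series: lipophilicity after hydroxy removal

The source may report more compounds than this note shows. Statements on the series, on what has been measured and on what is new or still open speak of the compounds shown alone.

Of the compounds shown here, three of the shared core have been measured in a physicochemical assay for lipophilicity, measured as octanol-water partition; a higher number here means a more lipophilic compound, a lower number a more polar compound. Compound 1 `CCOc1ccc(/C=N/NC(=O)COc2cccc3ccccc23)cc1O` gives 3.82 in this assay. Compound 2 `O=C(COc1cccc2ccccc12)N/N=C/c1ccc(O)cc1` gives 3.73 in this assay. Compound 3 `C/C(=N\NC(=O)COc1cccc2ccccc12)c1ccccc1` gives 3.65 in this assay. The three values sit close together: the gap from compound 2 to compound 3 and the gap from compound 2 to compound 1 both lie within the usual scatter, so no order among the three can be read from these numbers, and compound 2 stands in the middle of a flat set.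

The next compound is compound 4 `O=C(COc1cccc2ccccc12)N/N=C/c1ccccc1`, not yet measured in this assay. It differs from compound 2 in one place: hydrogen in place of hydroxy on an aromatic carbon. The change sits on an aromatic carbon of a six-membered aromatic ring of carbon only, para to a large group; cut one bond further out it reads 4-hydroxyphenyl to phenyl. For the measured compounds named here, no measured pair in the set shows this exact change, so nothing in the data fixes its size.

The step from compound 2 to compound 4 is expected to be a number 0.47 log units higher from compound 2 to compound 4 (beyond the scatter), upward and beyond the scatter. Compound 4 is therefore estimated at 4.2, with a range from 3.9 to 4.5.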

Compound 4, partition coefficient: 4.02
Compound 4: middle estimate off by 0.18 log units, on the high side; low and high end bracket the measured number.
By their numbers in this assay, from the lowest: compounds 3, 2, 1 and 4 (each within the scatter of the next, the first and the last beyond it).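

Hydrogen in place of hydroxy on an aromatic carbon, para to a large group, now has a direct reading in this assay: a number 0.29 log units higher from compound 2 to compound 4 (within the scatter). For the compounds shown here, this is the first one-place pair, and it shows that the exchange of 4-hydroxyphenyl for phenyl on the shared core, which removes one oxygen, one hydrogen-bond donor and one hydrogen-bond acceptor, gives a step that cannot be told apart from repeat measurement. No data at hand bear on why the step has this size.

The compounds shown leave open whether an amine, a carboxylic acid or a methoxy group on this same aromatic carbon would give a step beyond the scatter, since hydroxy and hydrogen are the only two groups compared there. They also leave open whether removing the hydroxy from compound 1, which carries an ethoxy group as well, would give a step of similar size, so this single pair supports no general rule for the series.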